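Swapping the aryl amide on a hexafluoro-carbinol naphthylamine core

The source may report more compounds than this note shows. Statements on the series, on what has been measured and on what is new or still open speak of the compounds shown alone.

Measured so far in an assay on LtK cells with ATP-sensitive inward rectifier potassium channel 11 (Homo sapiens) as the target; on this read-out lower numbers stand for an effect already at smaller amounts and higher numbers for an effect only at larger amounts of compound:
Compound 1, `CC(C)CCC(=O)Nc1c(C(O)(C(F)(F)F)C(F)(F)F)ccc2ccccc12`: 49 nM
Compound 2, `Cc1cccc(C(=O)Nc2c(C(O)(C(F)(F)F)C(F)(F)F)ccc3ccccc23)c1`: 23 nM
Compound 3, `O=C(Nc1c(C(O)(C(F)(F)F)C(F)(F)F)ccc2ccccc12)c1ccc(C(F)(F)F)cc1`: 160 nM

Compound 3 stands at the highest number of the three. Its nearest neighbour is compound 1, and the step of a 3.3-fold higher number from compound 1 to compound 3 (0.51 log units; beyond the scatter) shows how far apart they lie; compound 2 is furthest, as the step of a 7.0-fold higher number from compound 2 to compound 3 (0.84 log units; beyond the scatter) shows. Going by the values given here, the only other measured step, a 2.1-fold lower number from compound 1 to compound 2 (0.33 log units; beyond the scatter), is also beyond the scatter.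

Compound 4, `O=C(Nc1c(C(O)(C(F)(F)F)C(F)(F)F)ccc2ccccc12)c1cccc(Cl)c1Cl`, is not yet measured. It differs from compound 3 by 2,3-dichlorophenyl in place of 4-(trifluoromethyl)phenyl on a carbonyl carbon. Among the compounds with values here, no measured step exchanges one aryl for another aryl on this carbonyl carbon except the one from compound 2 to compound 3, in which replacing 3-methylphenyl with 4-(trifluoromethyl)phenyl gave the highest number of the set; the step from compound 1 to compound 3 points the same way. Since every other group on this carbonyl carbon gives a lower number than compound 3, a move away from the 4-(trifluoromethyl)phenyl is expected to bring the number down again, though by how much is uncertain, and the new aryl could also sit close to compound 3. Compound 4 is therefore estimated at 50 nM, between 15 nM and 160 nM, an expected step of a 3.2-fold lower number from compound 3 to compound 4 (0.51 log units; beyond the scatter).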

Compound 4, half-maximal effective concentration: > 10000 nM
Compound 4: a limit, no number; the forecaster's own chance of this, stated with the estimate: 5%; middle value at least 200-fold (2.30 log units) away from the limit.
By their numbers in this assay, from the lowest: compound 2; then compound 1; then compound 3. At a limit, above all of these: compound 4.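

In this assay compound 4 gives > 10000 nM, which is a limit of the assay and not a number: the limit of > 10000 nM in this assay, at which 1 of the 4 values shown sits.

Until now the isopentyl, 3-methylphenyl and 4-(trifluoromethyl)phenyl groups on this carbonyl carbon had all given readable values, whereas the 2,3-dichlorophenyl group shows that the same place can lose the read-out altogether, with an at least 62-fold higher number from compound 3 to compound 4 (1.79 log units; beyond the scatter), an at least 430-fold higher number from compound 2 to compound 4 (2.63 log units; beyond the scatter) and an at least 200-fold higher number from compound 1 to compound 4 (2.30 log units; beyond the scatter). Exchanging one aryl for another here, which was a modest change in a 7.0-fold higher number from compound 2 to compound 3 (0.84 log units; beyond the scatter), can therefore also be a large one, so an aryl group on this carbonyl carbon does not by itself secure a measurable value.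

The compounds shown do not tell whether both chlorines are needed for this loss, or whether a plain phenyl or a phenyl carrying a single chlorine would stay in the range of compound 1 to compound 3. On these data alone, how far compound 4 truly lies beyond its limit also stays open, so its three steps fix only the least size they can have.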